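The compounds below may be only part of what the source reports. "The series", "measured", "known", "first", "only" and "open" are said of these compounds alone.

Working notes on the series.

Within the data shown here, compound 2 `COc1cc2c(Oc3ccc(NC(=O)c4cn(-c5c(Cl)cccc5Cl)nn4)cc3F)ccnc2cc1OCCCN1CCCCC1` gives 280 nM in a functional assay on NCI-H460 cells (Homo sapiens) for cytotoxicity, read by MTT assay, with a stated time of 72 h (on this read-out lower numbers stand for stronger inhibition and higher numbers for weaker inhibition), the lowest of the two numbers measured so far. Among the measured compounds shown here, its nearest neighbour, compound 1 `COc1cc2c(Oc3ccc(NC(=O)c4cn(-c5c(C)cccc5C)nn4)cc3F)ccnc2cc1OCCCN1CCCCC1`, gives 3520 nM in this assay; the single measured step, a 13-fold lower number from compound 1 to compound 2 (1.10 log units; beyond the scatter), is a large one.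

Compound 3 `COc1cc2c(Oc3ccc(NC(=O)c4cn(-c5ccc(F)c(F)c5)nn4)cc3F)ccnc2cc1OCCCN1CCCCC1` is not yet measured. The change from compound 2 is 3,4-difluorophenyl in place of 2,6-dichlorophenyl on an aromatic nitrogen. For the measured compounds named here, the only measured step concerns a swap of methyl for chlorine on the same 2,6-pattern; compound 3 changes both the halogen and its placement on the ring, so that step bears on it only indirectly, and no measured pair covers the new pattern. A move away from the number of compound 2 is expected, most likely upward, of moderate size, with wide uncertainty.

For compound 3 the estimate in this assay is 1200 nM, range 300 nM to 5000 nM, the expected step being a 4.3-fold higher number from compound 2 to compound 3 (0.63 log units; beyond the scatter).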

Compound 3, half-maximal inhibitory concentration: 250 nM
Compound 3: the middle estimate sits 4.8-fold (0.68 log units) above what was measured; measured number below the stated range.
By their numbers in this assay, from the lowest: compounds 3 and 2 (each within the scatter of the next); then compound 1.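

In this assay, 3,4-difluorophenyl in place of 2,6-dichlorophenyl on the aromatic nitrogen gives a 1.1-fold lower number from compound 2 to compound 3 (0.05 log units; within the scatter), so this position accepts two different halogens in two different placements without a change beyond the scatter. Against the 2,6-dimethylphenyl group, the same position gives a 14-fold lower number from compound 1 to compound 3 (1.15 log units; beyond the scatter), which leaves compound 1 as the only one of the three set apart, with compound 2 and compound 3 reading alike. No measurement at hand explains why these groups read as they do.

On these data alone, it stays open whether the methyl groups themselves set compound 1 apart, and a 3,4-dimethylphenyl group would help to separate the substituent from its placement. Also open, as far as these compounds go, is how unsubstituted phenyl, or a phenyl carrying an amine or a carboxylic acid, would read in this assay.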